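A few compounds are considered here, and "the series" means these few. Any claim that something is new, unique, unknown or untested is made for them only; others in the source may bear on it.

Measured in a functional assay on MDA-MB-231 cells (Homo sapiens) for antiproliferative activity, read by MTT assay, with a stated time of 72 h; a higher number here means a weaker inhibitor, a lower number a stronger inhibitor:
- compound 1 `O=C(CCc1cccc2c1B(O)OC2)Nc1ccc(Br)cc1` gives 5300 nM
- compound 2 `CC(C)(C)c1ccc(NC(=O)CCc2cccc3c2B(O)OC3)cc1` gives 33000 nM
- compound 3 `O=C(CCc1cccc2c1B(O)OC2)Nc1cccc2ccccc12` gives 150 nM

Compound 2 has the highest number of the three in this assay, with compound 1 nearest and compound 3 furthest. The next structure is compound 4 `O=C(CCc1cccc2c1B(O)OC2)Nc1ccc(-c2ccccc2)cc1`, reached by phenyl in place of tert-butyl on an aromatic carbon.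

Among the measured compounds shown here, only one measured step bears directly on this place: a 6.2-fold higher number from compound 1 to compound 2 (0.79 log units; beyond the scatter), with tert-butyl in place of bromo. It is modest and shows that tert-butyl is the less favourable of those two groups. Compound 3 at 150 nM is not a matched comparison, but it shows that a much lower number is reachable with a different group on the amide. A modest to moderate step toward a lower number is therefore expected on losing tert-butyl, with wide uncertainty. The expected change is an 8.3-fold lower number from compound 2 to compound 4 (0.92 log units; beyond the scatter). The estimate for compound 4 is 4000 nM, with an expected range of 700 nM to 20000 nM.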

Compound 4, half-maximal inhibitory concentration: 8800 nM
The estimate for compound 4 lay 2.2-fold (0.34 log units) below the measured number; the range from low to high includes it.
By their numbers in this assay, from the lowest: compound 3; then compounds 1 and 4 (each within the scatter of the next); then compound 2.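

In this assay, phenyl in place of tert-butyl on an aromatic carbon, para to a large group, gives a 3.8-fold lower number from compound 2 to compound 4 (0.57 log units; beyond the scatter), a modest step, so the group with more heavy atoms of this pair gives the lower number at this place. Phenyl in place of bromo gives a 1.7-fold higher number from compound 1 to compound 4 (0.22 log units; within the scatter), which leaves these two groups indistinguishable here and tert-butyl as the only one of the three substituents set apart from the others. No measurement available on these compounds explains the result.

Open, on these data alone, is how an amine, a carboxylic acid or a methoxy group would read at this place. Also open, as far as these compounds go, is whether a chloro or fluoro group would track bromo, and whether any group here can approach the number of compound 3, 150 nM.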